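Compound 4 and its unsaturated ester side chain

The source may hold more compounds than are shown below. What is called first, only, known or untested is meant among the compounds shown, and "the series" means these compounds.

Measured in an ADME assay on HEK293 cells (Homo sapiens) for cytotoxicity, with a stated time of 72 h (on this read-out higher numbers stand for an effect only at larger amounts of compound and lower numbers for an effect already at smaller amounts), each value a limit of the assay:
Compound 1 `C=C[C@@](C)(/C=C/c1ccc(OC)cc1)CCC=C(C)C`: > 36600 nM
Compound 2 `C=C[C@@](C)(/C=C/c1ccc(OCc2ccccc2)cc1)CCC=C(C)C`: > 36600 nM
Compound 3 `C=C[C@@](C)(/C=C/c1ccc(O)cc1)CCC(O)C(C)(C)O`: > 36600 nM

Compound 3 has no number in this assay, only the limit > 36600 nM. The three measured compounds share a single reading, (the limit of > 36600 nM in this assay, at which 3 of the 3 values shown sit), so none can be ranked against another.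

Compound 4 `C=C[C@@](C)(/C=C/c1ccc(O)cc1)CC/C=C/C(=O)OCC` changes the side chain of compound 3: 2-(ethoxycarbonyl)ethenyl in place of 1,2-dihydroxy-2-methylpropyl on a saturated chain carbon, three bonds along the chain from two double-bonded chain carbons. Within the data shown here, the one measured step, a step that the two limits leave unreadable from compound 1 to compound 2, concerns a different change and has no readable size, so it offers no measure for this one. The data therefore point to no particular step beyond the scatter, and compound 4 may well report only a limit too. This expectation rests on compound 3 and its limit of > 36600 nM. If a number does appear, it can only lie towards smaller amounts of compound than that limit. The expected step, loosely estimated, is an at least 1.1-fold lower number from compound 3 to compound 4 (0.05 log units; that floor lies within the scatter). For compound 4 the estimated value is 32000 nM, with an expected range from 12000 nM to 60000 nM.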

Compound 4, half-maximal effective concentration: > 36600 nM
Compound 4: only a limit was reported; the forecaster's own chance of this, stated with the estimate: 65%; middle value at least 1.1-fold (0.05 log units) from the limit.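

Among these compounds, compound 4 reports only a limit of the assay (> 36600 nM), so no step from compound 3 to compound 4 can be read. The compounds shown leave open whether any change to the shared core would give a number in this assay at all: the limit of > 36600 nM in this assay, at which 4 of the 4 values shown sit.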